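Three Compounds at the Cytotoxicity Limit, and a Fourth

The source may report more compounds than this note shows. Statements on the series, on what has been measured and on what is new or still open speak of the compounds shown alone.

Three measured compounds share one core and differ only in a single group on an aromatic carbon. Compound 1 `CCOC(=O)CCCCCOc1cccc(CN(C(=O)c2ccccc2)C(C)C)c1` carries hydrogen at that place. In an ADME assay on Raji cells (Homo sapiens) for cytotoxicity, read by CellTiter-Glo and resazurin assay, with a stated time of 72 h (on this read-out higher numbers stand for an effect only at larger amounts of compound and lower numbers for an effect already at smaller amounts), compound 1 gives > 26000 nM, which is a limit of the assay and not a number. Compound 2 `CCOC(=O)CCCCCOc1cccc(CN(C(=O)c2ccc(-c3cccc(NC(C)=O)c3)cc2)C(C)C)c1` carries 3-acetamidophenyl there; in this assay compound 2 gives > 26000 nM, again a limit. Compound 3 `CCOC(=O)CCCCCOc1cccc(CN(C(=O)c2ccc(-c3ccc(C(C)=O)s3)cc2)C(C)C)c1` carries 5-acetylthiophen-2-yl; in this assay compound 3 gives > 26000 nM, also a limit. Compound 3 therefore stands exactly where the other two stand, since the limit of > 26000 nM in this assay, at which 3 of the 3 values shown sit, holds every value shown.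

Each step between these compounds joins two limits and so cannot be sized: a step that the two limits leave unreadable from compound 1 to compound 2, a step that the two limits leave unreadable from compound 1 to compound 3 and a step that the two limits leave unreadable from compound 2 to compound 3.

Compound 4 `CCOC(=O)CCCCCOc1cccc(CN(C(=O)c2ccc(-c3cccc(-c4nnc(C)o4)c3)cc2)C(C)C)c1` has not been measured. It differs from compound 3 by 3-(5-methyl-1,3,4-oxadiazol-2-yl)phenyl in place of 5-acetylthiophen-2-yl on an aromatic carbon. All three measured steps bear on this change, yet none gives a readable size or direction, so no shift beyond the scatter can be foreseen from them. Compound 4 is expected to remain at the limit in this assay, estimated at 26000 nM with a range from 13000 nM to 60000 nM. The step from compound 3 to compound 4 is therefore expected to be a number no higher from compound 3 to compound 4 (the limit leaves the size open).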

Compound 4, half-maximal effective concentration: > 26000 nM
Compound 4 was reported as a limit; the forecaster's own chance of this, stated with the estimate: 85%; the middle value lies on the limit itself.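

Compound 4 also sits at a limit of the assay, so its steps from compound 1, compound 2 and compound 3 join limit to limit and none can be read. The compounds shown leave open whether the group at this place changes the read-out at all, since all of them share one limit: the limit of > 26000 nM in this assay, at which 4 of the 4 values shown sit.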